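The source may hold more compounds than are shown below. What is called first, only, known or untested is meant among the compounds shown, and "the series" means these compounds.

Measured in a physicochemical assay for acid dissociation:

Compound 1 `COc1ccnc(C[S+]([O-])c2nc3cc(OCC(F)(F)F)ccc3[nH]2)c1OC`: 3.9
Compound 2 `COc1ccnc(C[S+]([O-])c2nc3cc(OC(F)(F)C(F)F)ccc3[nH]2)c1OC`: 3.86

Compound 2, at 3.86, stands within the scatter of compound 1. The next structure, compound 3 `COc1ccnc(C[S+]([O-])c2nc3cc(OC(F)(F)C(F)F)ccc3[nH]2)c1`, has hydrogen in place of methoxy on an aromatic carbon of compound 2: hydrogen in place of methoxy on an aromatic carbon. For the measured compounds named here, only one measured step exists, a number 0.04 log units lower from compound 1 to compound 2 (within the scatter). Going by the values given here, it concerns a different group and leaves the methoxy groups untouched, so it bears on this change only indirectly, and no measured step shows what losing a methoxy does. On this thin evidence, no step beyond the scatter is expected in this assay, and a higher read-out is not expected over a lower one, nor a lower over a higher. The expected step is a number 0.04 log units higher from compound 2 to compound 3 (within the scatter). For compound 3 the estimated value is 3.9, with an expected range from 3.5 to 4.3.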

Compound 3, acid dissociation constant: 4.25
For compound 3 the middle estimate is 0.35 log units below the measured one, and the stated range covers the measured number.
By their numbers in this assay, from the lowest: compounds 2 and 1 (each within the scatter of the next); then compound 3.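

In this assay hydrogen in place of methoxy on this aromatic carbon, two atoms from the ring nitrogen, gives a number 0.39 log units higher from compound 2 to compound 3 (beyond the scatter) and so moves the read-out beyond the scatter. The earlier change on the oxygen, a number 0.04 log units lower from compound 1 to compound 2 (within the scatter) by contrast, stayed within the scatter, so this position on the six-membered ring is the one of the two places that shifts the number in these compounds. Nothing available explains why this step occurs.

As far as these compounds go, it remains open whether an amine or a chlorine atom at this position would shift the read-out in the same direction as hydrogen, or by a similar amount. From the compounds shown here alone, it is also open whether the same replacement would give a similar step alongside 2,2,2-trifluoroethyl, or at the remaining methoxy group of compound 3 .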